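The compounds below may be only part of what the source reports. "The series", "measured", "known", "first", "only" and "open" are said of these compounds alone.

Of the compounds shown here, two of one shared core have been measured in a functional assay on MGC-803 cells (Homo sapiens) for inhibition, read by MTT assay, with a stated time of 72 h; on this read-out lower numbers stand for stronger inhibition and higher numbers for weaker inhibition. Compound 1 `Cc1cc(Nc2cc(-c3ccc(Cl)cc3)[nH]n2)n2nc(SCc3ccc(Br)cc3)nc2n1` carries a 4-chlorophenyl group and a bromobenzyl thioether; in this assay compound 1 gives 2780 nM. Compound 2 `Cc1cc(Nc2cc(-c3ccccc3)[nH]n2)n2nc(SCC(=O)c3ccccc3)nc2n1` carries a phenyl group and a phenacyl thioether; in this assay compound 2 gives 2580 nM. Compound 1 holds the higher of the two numbers, but its gap to compound 2 is within the scatter, so the two values show no difference that can be read as order.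

The next compound, compound 3 `Cc1cc(Nc2cc(C(C)(C)C)[nH]n2)n2nc(SCc3ccc(Br)cc3)nc2n1`, keeps the bromobenzyl thioether of compound 1 and changes only one position: tert-butyl in place of 4-chlorophenyl on an aromatic carbon. Within the data shown here, no pair of measured compounds differs in this way, so there is no measured step to lean on. Given that both measured values sit close together, the step from compound 1 to compound 3 is expected to be small, on the side of a somewhat higher number, estimated at a 1.4-fold higher number from compound 1 to compound 3 (0.16 log units; within the scatter). For compound 3 the expected value in this assay is 4000 nM, with a range from 1500 nM to 12000 nM.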

Compound 3, half-maximal inhibitory concentration: 5620 nM
The estimate for compound 3 lay 1.4-fold (0.15 log units) below the measured number, and the stated range covers the measured number.
By their numbers in this assay, from the lowest: compounds 2 and 1 (each within the scatter of the next); then compound 3.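

Among these compounds, with the bromobenzyl thioether held constant, the first reading at this position in this assay comes from putting tert-butyl in place of 4-chlorophenyl, which gives a 2.0-fold higher number from compound 1 to compound 3 (0.31 log units; beyond the scatter). The earlier compounds shown here offered no step at all, whereas this one shows that the group on this aromatic carbon, next to the ring nitrogen, does move the number, though only modestly: the change takes away the six-membered aromatic ring and the chlorine together and costs little more than the usual scatter. The compounds shown carry no measurement that would explain this step, so its size stands here as an observation only.

As far as these compounds go, what remains open is which part of the change matters, since the ring and the chlorine leave in one step, and a cyclohexyl group, a 4-methoxyphenyl group or a small methyl at this position would help to separate ring, substituent and size of group. From the compounds shown here alone, it also remains open whether the step would keep its direction and size with another group at the thioether, such as the phenacyl thioether of compound 2.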